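The source may report more compounds than this note shows. Statements on the series, on what has been measured and on what is new or still open speak of the compounds shown alone.

Four compounds share one core, seen in compound 1 `CCCNC(=C\C(=O)/C=C/c1ccc(O)c(OC)c1)/C=C/c1ccc(O)c(OC)c1`, and differ in the group on the amine nitrogen. In a functional assay on CHO-K1 cells (Cricetulus griseus) for inhibition, read by MTT assay, with a stated time of 72 h (on this read-out higher numbers stand for weaker inhibition and lower numbers for stronger inhibition), compound 1 gives only a limit of the assay, > 25000 nM. For the measured compounds named here, compound 3 `C=CCNC(=C\C(=O)/C=C/c1ccc(O)c(OC)c1)/C=C/c1ccc(O)c(OC)c1` returns a definite number in this assay, 7400 nM, and the step of an at least 3.3-fold lower number from compound 1 to compound 3 (0.52 log units; beyond the scatter) is the only measured change in the set with a size that can be stated. Compound 2 `CCC(C)NC(=C\C(=O)/C=C/c1ccc(OC(C)=O)c(OC)c1)/C=C/c1ccc(OC(C)=O)c(OC)c1` likewise gives only a limit in this assay, > 25000 nM. Two of the three values shown share this standing: the limit of > 25000 nM in this assay, at which 2 of the 3 values shown sit.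

Compound 4 `COc1cc(/C=C/C(=O)/C=C(/C=C/c2ccc(OC(C)=O)c(OC)c2)NC2CCCCC2)ccc1OC(C)=O` is compound 2 with cyclohexyl in place of sec-butyl on an amine nitrogen. Going by the values given here, no measured step replaces a saturated chain on the amine nitrogen by a ring; the one measured step concerns unsaturation in the chain, not its size, so it bears on this change only loosely and gives no direction. With compound 2 at the limit and nothing pointing toward a gain, the step of an at least 1.2-fold lower number from compound 2 to compound 4 (0.09 log units; that floor lies within the scatter) is expected to stay within the scatter. Compound 4 is therefore expected to give about 20000 nM, within 5000 nM to 60000 nM, with a fair chance that this assay again reports only a limit.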

Compound 4, half-maximal inhibitory concentration: 10100 nM
The estimate for compound 4 lay 2.0-fold (0.30 log units) above the measured number; measured number inside the range.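

The change on the amine nitrogen is not silent in this assay: cyclohexyl in place of sec-butyl gives an at least 2.4-fold lower number from compound 2 to compound 4 (0.39 log units; beyond the scatter), and this is the first step shown that puts a ring at this position. The earlier step concerned only vinyl in place of ethyl on the chain, on the core of compound 1, whereas this one shows that the group on the nitrogen also matters on the core of compound 2, which carries the acetyl esters. Compound 2 itself gives only a limit of the assay, so the size of this step is a floor, and that standing is shared: the limit of > 25000 nM in this assay, at which 2 of the 4 values shown sit.

The compounds shown leave open whether the ring itself matters or only the larger group, a question that an open hexyl chain on the same nitrogen would address, and how cyclopentyl or benzyl would compare with cyclohexyl. They also leave open whether cyclohexyl gives a similar step on the core of compound 1, with its free hydroxyl groups in place of the acetyl esters.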